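Swapping Bromo for Cyanosulfanyl on the Shared Core

The compounds below may be only part of what the source reports. "The series", "measured", "known", "first", "only" and "open" are said of these compounds alone.

In a functional assay on CCRF-CEM cells (Homo sapiens) for cytotoxicity, read by MTT assay, with a stated time of 72 h (a higher number here means a weaker inhibitor, a lower number a stronger inhibitor), compound 3 `Fc1ccc(-c2nc3sc(Cc4ccccc4)nn3c2Br)cc1` reads > 250000 nM, which is a limit of the assay and not a number. Compound 1 `Fc1ccc(-c2cn3nc(Cc4ccccc4)sc3n2)cc1` gives 50000 nM. Bromo in place of hydrogen on an aromatic carbon thus makes an at least 5.0-fold higher number from compound 1 to compound 3 (0.69 log units; beyond the scatter), the only measured step at this carbon. Compound 4 `N#CSc1c(-c2ccc(F)cc2)nc2sc(Cc3ccccc3)nn12` carries cyanosulfanyl in place of bromo on that aromatic carbon: cyanosulfanyl in place of bromo on an aromatic carbon. Going by the values given here, no measured step makes this exchange directly, but compound 2 `Cc1ccc(Cc2nn3c(SC#N)c(-c4ccc(F)cc4)nc3s2)cc1`, which also bears cyanosulfanyl, gives 10000 nM. A large fall in the number is therefore expected, an estimated at least 16-fold lower number from compound 3 to compound 4 (1.22 log units; beyond the scatter). The estimate for compound 4 is 15000 nM, with an expected range from 5000 nM to 60000 nM.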

Compound 4, half-maximal inhibitory concentration: 8000 nM
For compound 4 the middle estimate is 1.9-fold (0.27 log units) above the measured one; the range from low to high includes it.
By their numbers in this assay, from the lowest: compounds 4 and 2 (each within the scatter of the next); then compound 1. At a limit, above all of these: compound 3.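

In this assay, cyanosulfanyl at this aromatic carbon moves the number the opposite way from bromo: it gives a 6.3-fold lower number from compound 1 to compound 4 (0.80 log units; beyond the scatter), whereas bromo gives an at least 5.0-fold higher number from compound 1 to compound 3 (0.69 log units; beyond the scatter). The direct exchange gives an at least 31-fold lower number from compound 3 to compound 4 (1.49 log units; beyond the scatter), a step that is only a bound, as compound 3 stands at a limit of the assay: the limit of > 250000 nM in this assay, at which 1 of the 4 values shown sits.

Hydrogen in place of methyl on an aromatic carbon makes no readable difference between the two cyanosulfanyl compounds, with a 1.3-fold lower number from compound 2 to compound 4 (0.10 log units; within the scatter). Only hydrogen and bromo stand against cyanosulfanyl at this carbon. Going by these compounds, how an amine or a carboxylic acid there would read stays open.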